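Cytotoxicity notes on a shared-core series

A few compounds are considered here, and "the series" means these few. Any claim that something is new, unique, unknown or untested is made for them only; others in the source may bear on it.

Measured so far:
compound 1 `Cc1c(Cc2ccccc2)c(=O)oc2cc(OCC(O)CNc3ccccc3)ccc12`: > 100000 nM
compound 2 `Cc1c(Cc2ccc(F)cc2F)c(=O)oc2cc(OCC(O)CN3CCC(C(N)=O)CC3)ccc12`: > 100000 nM

In an ADME assay on A549 cells (Homo sapiens) for cytotoxicity, read by CellTiter-Glo (a lower number here means that less compound is tolerated, a higher number that more compound is tolerated), compound 1 returns only a limit, > 100000 nM. Compound 2 likewise returns only a limit in this assay, > 100000 nM. Compound 2 therefore stands where every shown value stands: the limit of > 100000 nM in this assay, at which 2 of the 2 values shown sit. Compound 3 `Cc1c(Cc2ccc(-c3ccccc3)cc2)c(=O)oc2cc(OCC(O)CN3CCC(C(N)=O)CC3)ccc12` is not yet measured. It differs from compound 2 in one place: 4-phenylphenyl in place of 2,4-difluorophenyl on a saturated chain carbon bound to an aromatic carbon. Going by the values given here, no step between measured compounds is available, so the size of this change in this assay cannot be read from the numbers; a step no larger than the usual scatter is expected, and an at least 1.2-fold lower number from compound 2 to compound 3 (0.09 log units; that floor lies within the scatter) is the step the estimate implies. Compound 3 is expected at 80000 nM, within 25000 nM to 200000 nM, most likely reported again only as a limit.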

Compound 3, half-maximal cytotoxic concentration: > 100000 nM
Compound 3 was reported as a limit; the forecaster's own chance of this, stated with the estimate: 60%; middle value at least 1.2-fold (0.09 log units) from the limit.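

Going by these compounds alone, compound 2 and compound 3 both return only limits in this assay, so no step between them can be read: the limit of > 100000 nM in this assay, at which 3 of the 3 values shown sit. The compounds shown leave open at what concentration any of them becomes cytotoxic to these cells.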